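Two aryl ketones measured, a dichloro analogue awaited

The source may report more compounds than this note shows. Statements on the series, on what has been measured and on what is new or still open speak of the compounds shown alone.

Compound 1 `COc1cc(-c2cc(/C=C/C(=O)c3ccc(N)cc3)[nH]n2)cc(OC)c1OC` was assessed in a functional assay on COLO 205 cells (Homo sapiens) for cytotoxicity, read by sulforhodamine B assay, with a stated time of 48 h, tested at 0.01 uM (on this read-out lower numbers stand for a stronger effect and higher numbers for a weaker effect at the one concentration tested), where compound 1 gives 93%. Its companion, compound 2 `COc1ccc(-c2cc(/C=C/C(=O)c3ccc(OC)c(OC)c3)[nH]n2)cc1`, was read in this assay as well, and there compound 2 gives 103%. Compound 1 thus has the lower of the two numbers, but its gap to compound 2 lies within the usual scatter, so the two cannot be ordered, and neither number points to a strong effect at the single concentration used. Compound 3 `COc1cc(-c2cc(/C=C/C(=O)c3ccc(Cl)c(Cl)c3)[nH]n2)cc(OC)c1OC` has not yet been measured. It differs from compound 1 in one place: 3,4-dichlorophenyl in place of 4-aminophenyl on a carbonyl carbon. Among the compounds with values here, no measured step touches this position, so nothing measured guides the expectation. For compound 3 the step from compound 1 is expected to be small, a number 2 percentage points higher from compound 1 to compound 3 (within the scatter), in no particular direction and not beyond the scatter. In this assay compound 3 is expected to give about 95%, within a range from 80% to 110%.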

Compound 3, a percentage reported as activity, at one concentration (the size of the read-out at that concentration, not a potency): 103%
Estimate against measurement, compound 3: 8 percentage points below, within the range that was stated.
By their numbers in this assay, from the lowest: compounds 1, 2 and 3 (each within the scatter of the next).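

On the carbonyl carbon, 3,4-dichlorophenyl in place of 4-aminophenyl gives a number 10 percentage points higher from compound 1 to compound 3 (within the scatter) in this assay. Within the data shown here, this is the first measured step at this position, and it shows that two quite different aryl groups, one with a hydrogen-bond donor and acceptor and one with two chlorine atoms and neither, cannot be told apart at the one concentration tested. No measurement given here bears on what lies behind this result.

The compounds shown leave open whether another group on this carbonyl carbon, such as a 4-hydroxyphenyl, a pyridine ring or a carboxylic acid on the phenyl ring, would carry the number beyond the scatter. They also leave open whether compound 1 and compound 3 would separate at a higher concentration.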